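The compounds below may be only part of what the source reports. "The series", "measured", "known", "first", "only" and "open" are said of these compounds alone.

Measured so far:
Compound 1 `CC1=C(C(=O)OC(C)(C)C)C(c2cccs2)NC(=O)N1` gives 26% in an assay on membranes from CHO cells for displacement of a labelled ligand from adenosine receptor A1 (Homo sapiens), read by scintillation counting, with a stated time of 60 min, tested at 1 uM; a lower number here means less inhibition, a higher number more inhibition at the concentration tested (going by the name of the read-out).
Compound 2 `CCSC(=O)C1=C(C)NC(=O)NC1c1ccco1` gives 6% in this assay.

Of these two numbers, compound 2 stands lowest; compound 1 lies a fair way higher, and that gap is beyond the usual scatter of repeated measurements. Compound 3 `CCSC(=O)C1=C(C)NC(=O)NC1c1cccs1` has not been measured yet. It arises from compound 2 by a single change: thiophen-2-yl in place of furan-2-yl on a saturated ring carbon. Within the data shown here, compound 1 carries the same thiophen-2-yl group but differs from compound 3 in a second place as well, so its value can only hint at what this group does; no step between two measured compounds isolates the change on its own. The expectation is therefore cautious: a rise in this assay beyond the scatter, yet smaller than the whole gap between compound 2 and compound 1, as the second difference between compound 1 and compound 3 is not separately measured. The step is expected to be a number 10 percentage points higher from compound 2 to compound 3 (within the scatter). Compound 3 is thus estimated at 16%, with a range from 2% to 34%.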

Compound 3, a percentage reported as inhibition, at one concentration (the size of the read-out at that concentration, not a potency): 6%
Compound 3: the middle estimate sits 10 percentage points above what was measured; low and high end bracket the measured number.
By their numbers in this assay, from the lowest: compounds 2 and 3 (each within the scatter of the next); then compound 1.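

Placing thiophen-2-yl in place of furan-2-yl on the saturated ring carbon, which exchanges the oxygen of the five-membered aromatic ring for sulfur, gives no change at the digits printed from compound 2 to compound 3 (within the scatter) in this assay, so with the ethylsulfanyl carbonyl group present, this assay does not separate the two rings. Among these compounds, compound 3 also provides the first comparison with compound 1 that involves only one place: thiophen-2-yl stays, while ethylsulfanyl in place of tert-butoxy on a carbonyl carbon gives a number 20 percentage points lower from compound 1 to compound 3 (beyond the scatter), which ties a real difference to the group on the carbonyl carbon in this thiophen-2-yl pair. Nothing available explains either result.

From the compounds shown here alone, it remains open whether a different group on the saturated ring carbon, such as phenyl or methyl, would move the reading away from that of the furan-2-yl and thiophen-2-yl compounds. The carbonyl step also swaps both the atom attached to the carbonyl carbon and the chain beyond it, so ethoxy or tert-butylsulfanyl at that carbon would be needed to tell those two parts apart.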